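Diethylamino in place of dimethylamino on compound 2

This account rests on a few compounds, and the source may have more. Where it says the series, first, only, none or still open, it means among the compounds named here.

Measured so far in a functional assay on MCF7 cells (Homo sapiens) for antiproliferative activity, read by MTT assay, with a stated time of 48 h; a higher number here means a weaker inhibitor, a lower number a stronger inhibitor:
compound 1 `CCn1c(C(=O)NCCCN(C)C)ccc1C(CC)(CC)c1ccc(OCCC(O)(CC)CC)c(C)c1` gives 3350 nM
compound 2 `CCn1c(C(=O)NCCN(C)C)ccc1C(CC)(CC)c1ccc(OCCC(O)(CC)CC)c(C)c1` gives 430 nM

Compound 2, at 430 nM, holds the lower of the two numbers, with compound 1 well above it. Compound 3 `CCN(CC)CCNC(=O)c1ccc(C(CC)(CC)c2ccc(OCCC(O)(CC)CC)c(C)c2)n1CC` has diethylamino in place of dimethylamino on a saturated chain carbon, two bonds along the chain from an amide-type nitrogen.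

Among the measured compounds shown here, one measured step bears on this, and only indirectly: a 7.8-fold lower number from compound 1 to compound 2 (0.89 log units; beyond the scatter) comes with dimethylamino in place of (dimethylamino)methyl at that same place. For the measured compounds named here, that step shows that this assay can respond to a single change in this chain, but no measured pair compares dimethylamino with diethylamino. Going by these compounds, no step beyond the scatter is therefore expected, and the direction remains open. The expected change is a 1.2-fold higher number from compound 2 to compound 3 (0.08 log units; within the scatter) in this assay on this reading. Compound 3 is estimated at 520 nM, with an expected range of 190 nM to 1400 nM at this stage.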

Compound 3, half-maximal inhibitory concentration: 550 nM
For compound 3 the middle estimate is 1.1-fold (0.02 log units) below the measured one; measured number inside the range.
By their numbers in this assay, from the lowest: compounds 2 and 3 (each within the scatter of the next); then compound 1.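

In this assay, the place on a saturated chain carbon, two bonds along the chain from an amide-type nitrogen, takes diethylamino as well as dimethylamino with no step beyond the scatter: a 1.3-fold higher number from compound 2 to compound 3 (0.11 log units; within the scatter), even though the heavy-atom count of the group goes from 3 to 5. The step from the (dimethylamino)methyl compound also holds with diethylamino, at a 6.1-fold lower number from compound 1 to compound 3 (0.78 log units; beyond the scatter), so the separation of compound 1 from the others in the series is not confined to its comparison with the dimethylamino compound. No measurement is available here that would explain either step.

The compounds shown do not tell how far this tolerance extends, for instance whether a dipropylamino group or a carboxylic acid at the same place would stay within the scatter of compound 2 and compound 3. They also leave open whether diethylamino on the chain of compound 1 would give a number close to that of compound 1 or close to those of compound 2 and compound 3.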